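The source may hold more compounds than are shown below. What is called first, only, known or untested is meant among the compounds shown, and "the series" means these compounds.

Measured compounds:
- compound 1, `CCCOCCn1c(N2CCN(C)CC2)nc2ccccc21`: 20 nM
- compound 2, `CCCCCCn1c(N2CCN(C)CC2)nc2ccccc21`: 26 nM
- compound 3, `CCCCOCCn1c(N2CCN(C)CC2)nc2ccccc21`: 38 nM

All three were measured in a functional assay on ileum for inhibition of histamine H1 receptor (Cavia porcellus); a higher number here means a weaker inhibitor, a lower number a stronger inhibitor. Compound 3 gives the highest of the three numbers, but the step of a 1.5-fold higher number from compound 2 to compound 3 (0.16 log units; within the scatter) and the step of a 1.9-fold higher number from compound 1 to compound 3 (0.28 log units; within the scatter) both stay within the scatter, so the three compounds cannot be ranked. The step of a 1.3-fold higher number from compound 1 to compound 2 (0.11 log units; within the scatter) is likewise within the scatter.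

Compound 4, `CN1CCN(c2nc3ccccc3[nH]2)CC1`, has not yet been measured. It differs from compound 3 in one place: hydrogen in place of 2-butoxyethyl on an aromatic nitrogen, on an aromatic nitrogen of a five-membered aromatic ring with two nitrogens, part of a fused system of two rings, next to the ring atom that bears the 4-methylpiperazin-1-yl group.

The measured steps only exchange one chain for another on that nitrogen, and none of them moves beyond the scatter. Among the measured compounds shown here, removing the chain altogether is a larger change for which there is no measured precedent, so the expected outcome is uncertain. The step from compound 3 is estimated as a 13-fold higher number from compound 3 to compound 4 (1.12 log units; beyond the scatter), in the direction of a higher number. Compound 4 is therefore expected to give about 500 nM, with a range from 60 nM to 5000 nM.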

Compound 4, half-maximal inhibitory concentration: > 3000 nM
Compound 4: no number, only a limit (the forecaster's own chance of this, stated with the estimate: 20%); at least 6.0-fold (0.77 log units) between middle value and limit.
By their numbers in this assay, from the lowest: compounds 1, 2 and 3 (each within the scatter of the next). At a limit, above all of these: compound 4.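

Compound 4 gives no number in this assay, only a limit: the limit of > 3000 nM in this assay, at which 1 of the 4 values shown sits.
Until now the aromatic nitrogen had only carried one chain in place of another, with no step beyond the scatter, whereas removing the chain altogether gives an at least 78-fold higher number from compound 3 to compound 4 (1.89 log units; beyond the scatter) together with an at least 110-fold higher number from compound 2 to compound 4 (2.06 log units; beyond the scatter) and an at least 150-fold higher number from compound 1 to compound 4 (2.17 log units; beyond the scatter) in the same direction, all of them large. Among these compounds, then, having a chain on this nitrogen matters far more in this assay than whether that chain is hexyl, 2-propoxyethyl or 2-butoxyethyl.

Nothing shown lies between hydrogen and these chains, so it remains open how a methyl or ethyl group on that nitrogen would behave. Also open, as far as these compounds go, is whether an amine or a carboxylic acid at the end of the chain would be tolerated.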